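The source may hold more compounds than are shown below. What is called first, only, known or untested is meant among the compounds shown, and "the series" means these compounds.

Compound 1 `Oc1cccc(-c2cc(-c3cccc(Cl)c3)nc(-c3ccco3)c2)c1`: 2020 nM
Compound 2 `Oc1cccc(-c2cc(-c3cccc(Cl)c3)nc(-c3cccs3)c2)c1`: 2650 nM

Of the compounds shown here, two sharing the same core have been measured in a functional assay on DU-145 cells (Homo sapiens) for cytotoxicity, read by CCK-8 assay and cell counting, with a stated time of 2 days; a lower number here means a stronger inhibitor, a higher number a weaker inhibitor. Compound 1 gives 2020 nM, the lowest of the two numbers shown; compound 2 gives 2650 nM, and the step of a 1.3-fold higher number from compound 1 to compound 2 (0.12 log units; within the scatter) does not separate the two. Within the data shown here, that single step concerns the exchange of the furan-2-yl group for thiophen-2-yl and is the only measured comparison available.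

Compound 3 `Oc1cccc(-c2cc(-c3ccco3)nc(-c3ccccc3Cl)c2)c1` has not yet been measured. It differs from compound 1 by 2-chlorophenyl in place of 3-chlorophenyl on an aromatic carbon. Among the measured compounds shown here, no measured step touches the chlorophenyl group, so the data give no direct guide to this change; the one step that is known, from compound 1 to compound 2, sits within the scatter, which suggests that small changes around this core have so far produced little movement. On that basis compound 3 is expected to land close to compound 1, with the step of a 1.1-fold higher number from compound 1 to compound 3 (0.06 log units; within the scatter) not beyond the scatter. The estimate for compound 3 in this assay is 2300 nM, expected to fall between 1000 nM and 5500 nM.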

Compound 3, half-maximal inhibitory concentration: 1630 nM
Compound 3: the middle estimate sits 1.4-fold (0.15 log units) above what was measured; measured number inside the range.
By their numbers in this assay, from the lowest: compounds 3, 1 and 2 (each within the scatter of the next).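

In this assay, the exchange of 3-chlorophenyl for 2-chlorophenyl on the aromatic carbon next to the ring nitrogen gives a 1.2-fold lower number from compound 1 to compound 3 (0.09 log units; within the scatter). Among these compounds, this is the first measured change at the chlorophenyl group, and it does not separate the two compounds, so this position tolerates the change of chlorophenyl isomer without a measurable shift in this cell assay. It joins the exchange of furan-2-yl for thiophen-2-yl, a 1.3-fold higher number from compound 1 to compound 2 (0.12 log units; within the scatter), so neither of the two changes measured around the shared core moves the number beyond the scatter, and no evidence bears on this result.

From the compounds shown here alone, all three compounds carry the 3-hydroxyphenyl group and a chlorophenyl group, so it remains open what a methoxy group or an amine in place of that hydroxyl would do, and what 4-chlorophenyl, plain phenyl or a saturated alkyl chain would do at the position of the chlorophenyl group. Going by these compounds, it also remains open whether any change to the shared core can move the number beyond the scatter in either direction.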